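Allyl in place of methyl on the shared core

The compounds below may be only part of what the source reports. "The series", "measured", "known", "first", "only" and "open" are said of these compounds alone.

Compound 1 `COc1ccccc1/C=c1\c(=O)[nH]/c(=C/c2cccc(Cl)c2Cl)c(=O)n1C` carries a methyl group on one ring nitrogen of its core and a hydrogen on the other. In a functional assay on NCI-H1975 cells (Homo sapiens) for cytotoxicity, read by CCK-8 assay, with a stated time of 72 h (a lower number here means a stronger inhibitor, a higher number a weaker inhibitor), compound 1 gives 300 nM, which is the only numerical result among the compounds discussed here. Compound 2 `COc1ccccc1/C=c1/[nH]c(=O)/c(=C\c2cccc(Cl)c2Cl)[nH]c1=O` has hydrogen on both ring nitrogens, and in this assay compound 2 is reported as "not active" (no number reported). Compound 3 `C=CCn1c(=O)/c(=C\c2ccc(Cl)c(Cl)c2)[nH]c(=O)/c1=C\c1ccccc1OC` carries an allyl group on one ring nitrogen and a different arrangement of the two chlorine atoms, and in this assay compound 3 is likewise reported as "not active" (no number reported). For the measured compounds named here, these two results give no number, so no measured step can be drawn between any pair.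

Compound 4 `C=CCn1c(=O)/c(=C\c2cccc(Cl)c2Cl)[nH]c(=O)/c1=C\c1ccccc1OC` differs from compound 1 in a single place: vinyl in place of hydrogen on a saturated chain carbon bound to an aromatic nitrogen. Read one bond further out, this is methyl to allyl. Going by the values given here, no measured pair shows what this exchange does. Since compound 3, which also bears an allyl group, shows "not active" (no number reported), a step toward weaker inhibition of a size that may reach beyond the scatter is expected, though a result within the scatter cannot be ruled out. The estimate for compound 4 is 700 nM, with a range from 150 nM to 4000 nM, which means an expected step of a 2.3-fold higher number from compound 1 to compound 4 (0.37 log units; beyond the scatter).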

Compound 4, half-maximal inhibitory concentration: 4500 nM
Compound 4: the middle estimate sits 6.4-fold (0.81 log units) below what was measured, and the stated range ends below it.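

In this assay, going from methyl to allyl on the saturated chain carbon bound to an aromatic nitrogen gives a large step, a 15-fold higher number from compound 1 to compound 4 (1.18 log units; beyond the scatter), so this place is sensitive to a change of only a few atoms. Even so, compound 4 keeps a measurable value, and the allyl group alone therefore does not account for the "not active" entry of compound 3, which differs from compound 4 in the arrangement of its two chlorine atoms. Nothing available explains why the number rises with this change.

The compounds shown leave open whether the double bond of the allyl group matters or whether any group larger than methyl gives a similar step, a question that an ethyl or propyl group at this place would address. They also leave open how this assay would respond to a chain ending in an amine or a carboxylic acid, and whether the same step would appear with the chlorine arrangement of compound 3.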